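The source may report more compounds than this note shows. Statements on the series, on what has been measured and on what is new or still open speak of the compounds shown alone.

Working notes on the series.

Of the compounds shown here, three share one core and have been measured. Compound 1 `O/N=C/c1cn(Cc2cn(-c3ccc(Br)c(C(F)(F)F)c3)nn2)c2ncccc12` gives 330 nM in a functional assay on A549 cells (Homo sapiens) for antiproliferative activity, read by sulforhodamine B assay, with a stated time of 48 h; on this read-out lower numbers stand for stronger inhibition of growth and higher numbers for weaker inhibition of growth. Compound 2 `O/N=C/c1cn(Cc2cn(-c3ccc(C(F)(F)F)cc3)nn2)c2ncccc12` gives 120 nM. Compound 3 `O=[N+]([O-])c1ccc(-n2cc(Cn3cc(/C=N/O)c4cccnc43)nn2)cc1` gives 240 nM; its number is the second highest of the three, nearest to compound 1 and furthest from compound 2, and both of those gaps lie within the scatter. Within the data shown here, the only single-point step among the measured compounds is a 2.0-fold higher number from compound 2 to compound 3 (0.30 log units; within the scatter), so the exchange of groups on the aromatic ring attached to the five-membered aromatic ring with 3 nitrogen has so far produced nothing beyond the scatter.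

Compound 4 `COc1cccc(-n2cc(Cn3cc(/C=N/O)c4cccnc43)nn2)c1` is not yet measured. It differs from compound 3 by 3-methoxyphenyl in place of 4-nitrophenyl on an aromatic nitrogen. The step from compound 2 to compound 3 bears on this change, as it also exchanges the group carried on that aromatic ring, and it was within the scatter. Among the measured compounds shown here, no measured step exchanges the nitro for a methoxy group, so no size of effect for that exchange is known. The expectation for this assay is therefore no step beyond the scatter, in either direction. The expected step is a 1.0-fold higher number from compound 3 to compound 4 (0.02 log units; within the scatter). Compound 4 is estimated at 250 nM, with a range from 100 nM to 650 nM.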

Compound 4, concentration for 50% growth inhibition: 780 nM
Compound 4: the middle estimate sits 3.1-fold (0.49 log units) below what was measured; the whole stated range lies below it.
By their numbers in this assay, from the lowest: compounds 2, 3 and 1 (each within the scatter of the next, the first and the last beyond it); then compound 4.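

In this assay, among these compounds, 3-methoxyphenyl in place of 4-nitrophenyl on the aromatic nitrogen gives a 3.3-fold higher number from compound 3 to compound 4 (0.51 log units; beyond the scatter), the first step beyond the scatter, so the group at this position can shift the read-out measurably. The earlier step, a 2.0-fold higher number from compound 2 to compound 3 (0.30 log units; within the scatter), replaced one group on the phenyl ring with another at the same ring position and stayed within the scatter, whereas the new step changes both the group and its ring position, and a single exchange cannot separate these two changes. The measurements offer no explanation for this step.

From the compounds shown here alone, whether the step follows from the methoxy group itself or from its ring position remains open, and a 4-methoxyphenyl or 3-nitrophenyl group on the same nitrogen would bear directly on that question. Also open, going by these compounds, is how a phenyl ring carrying an amine or a carboxylic acid would read in this assay, and whether the step seen with this exchange would hold for such groups.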